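The source may report more compounds than this note shows. Statements on the series, on what has been measured and on what is new or still open speak of the compounds shown alone.

Measured so far in an assay on isolated protein for inhibition of phosphodiesterase 4A (Sus scrofa); on this read-out higher numbers stand for weaker inhibition and lower numbers for stronger inhibition:
compound 1 `COc1ccc(C(=O)Nc2c(F)cccc2F)cc1OC1CCCC1` gives 70 nM
compound 2 `COc1ccc(C(=O)Nc2c(F)cccc2F)cc1OC` gives 900 nM

Within the data shown here, compound 1 stands at the lower of the two numbers; the one step known from it is a 13-fold higher number from compound 1 to compound 2 (1.11 log units; beyond the scatter), a change on an oxygen on an aromatic ring. Compound 3 `COc1ccc(C(=O)Nc2ccncc2Cl)cc1OC1CCCC1` differs from compound 1 elsewhere: 3-chloropyridin-4-yl in place of 2,6-difluorophenyl on an amide-type nitrogen. Among the measured compounds shown here, no measured step alters the group on the amide-type nitrogen, so the step to compound 2 does not bear on this change, and the data give no direction for it. Compound 3 is therefore expected close to compound 1, with an expected step of a 1.8-fold lower number from compound 1 to compound 3 (0.24 log units; within the scatter) that stays within the scatter. The estimate for compound 3 in this assay is 40 nM, with a range from 8 nM to 200 nM.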

Compound 3, half-maximal inhibitory concentration: 16 nM
Compound 3: middle estimate off by 2.5-fold (0.40 log units), on the high side, within the range that was stated.
By their numbers in this assay, from the lowest: compound 3; then compound 1; then compound 2.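

The group on the amide-type nitrogen proves able to move the number in this assay: 3-chloropyridin-4-yl in place of 2,6-difluorophenyl gives a 4.4-fold lower number from compound 1 to compound 3 (0.64 log units; beyond the scatter) and so lies beyond the scatter. The earlier compounds shown here gave no direction at this position, and the change now points to the lower number. Nothing at hand explains this step.

The compounds shown leave open whether the ring nitrogen or the chlorine carries the step, as both enter together. Also open, as far as these compounds go, is how a 3,5-dichloropyridin-4-yl group at this place would read, and whether the step holds with methyl on the oxygen.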